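The source may hold more compounds than are shown below. What is called first, only, known or untested is meant among the compounds shown, and "the series" means these compounds.

Working notes on the series. Compound 3 `C=CCn1c(=O)/c(=C\c2cccc(Br)c2)[nH]c(=O)/c1=C\c1ccccc1OC` holds the lower of the two numbers recorded in a functional assay on MOLT-4 cells (Homo sapiens) for cytotoxicity, read by CCK-8 assay, with a stated time of 72 h; on this read-out lower numbers stand for stronger inhibition and higher numbers for weaker inhibition: compound 3 gives 5000 nM, while compound 1 `C=CCn1c(=O)/c(=C\c2cccc(C)c2)[nH]c(=O)/c1=C\c1ccccc1OC` gives 16000 nM. Going by the values given here, the only single-point step recorded, a 3.2-fold lower number from compound 1 to compound 3 (0.51 log units; beyond the scatter), came from bromo in place of methyl on an aromatic carbon. Compound 2 `C=CCn1c(=O)/c(=C\c2ccc(Cl)c(Cl)c2)[nH]c(=O)/c1=C\c1ccccc1` returned "not active" (no number reported) in this assay, so no number stands for it.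

Compound 4 `C=CCn1c(=O)/c(=C\c2ccc(Cl)c(Cl)c2)[nH]c(=O)/c1=C\c1ccccc1OC` is to be measured next. The change from compound 3 is 3,4-dichlorophenyl in place of 3-bromophenyl on a double-bonded chain carbon bound to an aromatic carbon. Among the compounds with values here, no recorded step bears directly on this exchange: the only measured step concerns a different substituent swap, and compound 2, which carries the same 3,4-dichlorophenyl, differs from compound 4 in a second place as well and gave no number. The expectation therefore leans on compound 2 having shown "not active" (no number reported), and a weaker result than compound 3 is anticipated, with a fair chance that no number is returned at all. The estimated step is a 2.4-fold higher number from compound 3 to compound 4 (0.38 log units; beyond the scatter). For compound 4 the expected value in this assay is 12000 nM, within the range 3000 nM to 50000 nM.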

Compound 4, half-maximal inhibitory concentration: "not active" (no number reported)
Nothing numeric was reported for compound 4; there is nothing to compare the estimate with.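

Going by these compounds alone, compound 4, like compound 2, returned no number in this assay, so no step from compound 3 to compound 4 can be read. No measured evidence bears on this result. The compounds shown leave open how far compound 4 lies from compound 3 on this read-out.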